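The source may hold more compounds than are shown below. What is called first, only, known or untested is meant among the compounds shown, and "the series" means these compounds.

Compound 1 `O=C(Nc1cccc(OCc2cn(-c3ccccc3)nn2)c1)Nc1ccc(Cl)c(C(F)(F)F)c1`, compound 2 `CCc1ccccc1-n1cc(COc2cccc(NC(=O)Nc3ccc(Cl)c(C(F)(F)F)c3)c2)nn1` and compound 3 `CC(C)c1ccc(-n2cc(COc3cccc(NC(=O)Nc4ccc(Cl)c(C(F)(F)F)c4)c3)nn2)cc1` share one core and differ only on the phenyl ring attached to the triazole nitrogen. In a functional assay on HepG2 cells (Homo sapiens) for inhibition, read by MTT assay, with a stated time of 72 h (on this read-out higher numbers stand for weaker inhibition and lower numbers for stronger inhibition), compound 1 gives 1780 nM, compound 2 gives 3530 nM and compound 3 gives 2470 nM. Compound 3 thus holds the second highest of the three numbers: its nearest neighbour is compound 1, reached by a 1.4-fold higher number from compound 1 to compound 3 (0.14 log units; within the scatter), and its furthest is compound 2, with a 1.4-fold lower number from compound 2 to compound 3 (0.16 log units; within the scatter). Compound 4 `O=C(Nc1cccc(OCc2cn(-c3ccc(Cl)cc3)nn2)c1)Nc1ccc(Cl)c(C(F)(F)F)c1` arises from compound 3 through (chloro in place of isopropyl on an aromatic carbon). The steps that speak to this change are those that alter the same phenyl ring: a 2.0-fold higher number from compound 1 to compound 2 (0.30 log units; within the scatter), a 1.4-fold higher number from compound 1 to compound 3 (0.14 log units; within the scatter) and a 1.4-fold lower number from compound 2 to compound 3 (0.16 log units; within the scatter), none of which leaves the scatter. On that basis compound 4 is expected to show no step beyond the scatter in this assay, namely a 1.2-fold lower number from compound 3 to compound 4 (0.09 log units; within the scatter). Compound 4 is therefore estimated at 2000 nM, within a range from 900 nM to 4500 nM.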

Compound 4, half-maximal inhibitory concentration: 2490 nM
Beside the measured number, compound 4's estimate is 1.2-fold (0.10 log units) below it; measured number inside the range.
By their numbers in this assay, from the lowest: compounds 1, 3, 4 and 2 (each within the scatter of the next).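

In this assay, swapping the isopropyl for chloro, a single chlorine in place of three carbons at this position on the aromatic ring, leaves the number flat, with a 1.0-fold higher number from compound 3 to compound 4 (0.00 log units; within the scatter) as the step. The chloro group also stays level with the unsubstituted ring, giving a 1.4-fold higher number from compound 1 to compound 4 (0.15 log units; within the scatter), and with the 2-ethylphenyl group on the triazole nitrogen, giving a 1.4-fold lower number from compound 2 to compound 4 (0.15 log units; within the scatter), so a halogen joins the alkyl groups among the changes on this ring that do not leave the scatter. No measurement at hand accounts for this flat result.

The compounds shown leave open whether anything on this ring can move the number beyond the scatter at all. An amine, a carboxylic acid or a longer alkyl chain at this position could test that.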